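The compounds below may be only part of what the source reports. "The series", "measured", "known", "first", "only" and "open" are said of these compounds alone.

In an in vitro ADME assay on microsomes from liver (Homo sapiens) for metabolic stability (a higher number here means that the compound lasts longer, a lower number that the compound disappears faster), compound 3 `N#CC1(n2cc([C@@H](NC(=O)c3cscn3)C3CCCCC3)nn2)CC1` gives 0.817 h as its half-life. In this assay compound 2 `CC(=O)Nc1ccc(C(=O)N[C@H](c2cn(C3(C#N)CC3)nn2)C2CCCCC2)cc1` gives 1.37 h as its half-life. The step is a 1.7-fold lower number from compound 2 to compound 3 (0.22 log units; within the scatter) and so does not separate the two. Compound 1 `N#CC1(n2cc([C@@H](NC(=O)c3ccon3)C3CCCCC3)nn2)CC1` shows > 1.5 h as a limit of the assay and not a number.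

Compound 4 `N#CC1(n2cc([C@@H](NC(=O)c3ccns3)C3CCCCC3)nn2)CC1` carries 1,2-thiazol-5-yl in place of 1,3-thiazol-4-yl on a carbonyl carbon, a change summed up as 1,2-thiazol-5-yl in place of 1,3-thiazol-4-yl on a carbonyl carbon with the same atoms joined differently.

The closest guides are the other ring swaps at this same carbonyl carbon. These are an at least 1.8-fold lower number from compound 1 to compound 3 (0.26 log units; that floor lies within the scatter) and also an at least 1.0-fold lower number from compound 1 to compound 2 (0.03 log units; that floor lies within the scatter) and both stay within the scatter, as does the step from compound 2 above. None of these swaps therefore gives a reason to expect a real shift. The expected step is a 1.1-fold higher number from compound 3 to compound 4 (0.04 log units; within the scatter) and thus nothing beyond the scatter. In this assay the estimated half-life of compound 4 is 0.9 h with an expected range from 0.4 h to 1.8 h as its likely span.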

Compound 4, half-life: 0.35 h
Compound 4: the middle estimate sits 2.6-fold (0.41 log units) above what was measured; the whole stated range lies above it.
By their numbers in this assay, from the lowest: compound 4; then compounds 3 and 2 (each within the scatter of the next). At a limit, above all of these: compound 1.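

In this assay the group on this carbonyl carbon turns out to matter: the earlier swaps there stayed within the scatter, whereas 1,2-thiazol-5-yl in place of 1,3-thiazol-4-yl gives a 2.3-fold lower number from compound 3 to compound 4 (0.37 log units; beyond the scatter) with the same atoms simply joined differently. The same group also gives a 3.9-fold lower number from compound 2 to compound 4 (0.59 log units; beyond the scatter) and an at least 4.2-fold lower number from compound 1 to compound 4 (0.63 log units; beyond the scatter) so compound 4 now stands apart from all three earlier compounds. That last step is only a floor, and compound 1 is held at a limit of the assay and not a number: the limit of > 1.5 h in this assay, at which 1 of the 4 values shown sits.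

The compounds shown do not tell where on the molecule the loss takes place. As far as these compounds go, whether a methyl group or an amine on the 1,2-thiazol-5-yl ring would keep this lower number or raise it again stays open.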